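A few compounds are considered here, and "the series" means these few. Any claim that something is new, unique, unknown or untested is made for them only; others in the source may bear on it.

Of the compounds shown here, three have been measured in a functional assay on KB 3-1 cells (Homo sapiens) for cytotoxicity, read by MTT assay, with a stated time of 68 h; on this read-out lower numbers stand for stronger inhibition and higher numbers for weaker inhibition. Compound 1 (`COc1ccc(-c2cc(NC(=O)C(Cl)Cl)cc(-c3ccc(OC)c(F)c3)c2)cc1F`) gives 2940 nM, compound 2 (`Nc1cccc(-c2cccc(NC(=O)C(Cl)Cl)c2)c1`) gives 26100 nM, and compound 3 (`O=C(Nc1cccc(-c2ccccc2C(F)(F)F)c1)C(Cl)Cl`) gives 35900 nM. Compound 3 and compound 2 lie within the usual scatter of each other, and both stand well above compound 1, so compound 3 belongs to the weak end of this small set.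

Compound 4 (`Cc1ccccc1-c1cccc(NC(=O)C(Cl)Cl)c1`) is compound 3 with methyl in place of trifluoromethyl on an aromatic carbon, ortho to a large group: methyl in place of trifluoromethyl on an aromatic carbon. Within the data shown here, no measured pair shows this exchange, so the data give no direct size for it. The best available anchor is therefore compound 3 itself, at 35900 nM, and no change beyond the scatter is expected in this assay. The expected change is small, a 1.2-fold lower number from compound 3 to compound 4 (0.08 log units; within the scatter), and its direction is uncertain. For compound 4 the estimated value is 30000 nM, with an expected range from 13000 nM to 65000 nM.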

Compound 4, half-maximal inhibitory concentration: 42000 nM
The estimate for compound 4 lay 1.4-fold (0.15 log units) below the measured number; the range from low to high includes it.
By their numbers in this assay, from the lowest: compound 1; then compounds 2, 3 and 4 (each within the scatter of the next).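

With methyl in place of trifluoromethyl on an aromatic carbon, ortho to a large group, this assay gives a 1.2-fold higher number from compound 3 to compound 4 (0.07 log units; within the scatter). Among these compounds, this is the first direct reading of this exchange in the set: at this position, a group of 1 heavy atom and a group of 4 heavy atoms cannot be told apart in this assay. Nothing measured here explains the result, so no cause can be given for it.

From the compounds shown here alone, both groups have 0 hydrogen-bond donors and 0 hydrogen-bond acceptors, so it remains open whether a hydroxyl or a carboxylic acid at this position would give a number beyond the scatter from compound 3. Going by these compounds, it also remains open whether the same exchange would give a similarly small step on the core of compound 1.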